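This account rests on a few compounds, and the source may have more. Where it says the series, first, only, none or still open, it means among the compounds named here.

Measured compounds:

compound 1, `Clc1ncc(OCC2CCCN2)cc1/C=C/c1ccncc1`, in an assay for binding affinity to Neuronal acetylcholine receptor; alpha4/beta2 (Rattus norvegicus) (on this read-out higher numbers stand for weaker inhibition and lower numbers for stronger inhibition), gives 0.015 nM
compound 2, `CN1CCCC1COc1cnc(Cl)c(/C=C/c2ccncc2)c1`, gives 0.028 nM
compound 3, `Clc1ncc(OCC2CCCN2)cc1CCc1ccncc1`, gives 0.011 nM

Compound 1 and compound 2 differ by one change, (methyl in place of hydrogen on an amine nitrogen in a ring), and that change gave a 1.9-fold higher number from compound 1 to compound 2 (0.27 log units; within the scatter). The difference between the core of compound 1 and the core of compound 3 is not broken down here; the two values of compound 3 and compound 1 lie within the scatter of each other, while compound 3 and compound 2 lie beyond it.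

Compound 4, `CN1CCCC1COc1cnc(Cl)c(CCc2ccncc2)c1`, has not yet been measured. It differs from compound 3 by methyl in place of hydrogen on an amine nitrogen in a ring, the same change, at the same place, as from compound 1 to compound 2. Because that earlier change gave a 1.9-fold higher number from compound 1 to compound 2 (0.27 log units; within the scatter), a step of about the same size is expected here, namely a 1.9-fold higher number from compound 3 to compound 4 (0.28 log units; within the scatter). For compound 4 the expected value is therefore 0.021 nM, with a likely range from 0.01 nM to 0.045 nM.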

Compound 4, inhibition constant: 0.023 nM
For compound 4 the middle estimate is 1.1-fold (0.04 log units) below the measured one; the measured number falls inside the stated range.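

In this assay, methyl in place of hydrogen on the amine nitrogen gave a 2.1-fold higher number from compound 3 to compound 4 (0.32 log units; beyond the scatter), and this step can be set beside the earlier one: the same change on two cores in this assay, a 1.9-fold higher number (0.27 log units; within the scatter) from compound 1 to compound 2 and a 2.1-fold higher number (0.32 log units; beyond the scatter) from compound 3 to compound 4, 1.1-fold (0.05 log units) apart, within the scatter of two such steps. On these two cores, then, the change carried over with much the same size. Among these compounds, this rests on only two pairs of compounds, so it does not show that the step would hold on other cores, nor why it has this size.

Still open, going by these compounds, is how this assay would read with a larger group on that nitrogen, such as ethyl or benzyl. On these data alone, it is also open whether such a group would give similar steps on the two cores.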